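Swapping fluoro for methoxy on a shared oxime core

This account rests on a few compounds, and the source may have more. Where it says the series, first, only, none or still open, it means among the compounds named here.

Of the compounds shown here, three from one series have been measured in a functional assay (Mus musculus, strain Balb/c) for inhibition, read by ELISA, with a stated time of 72 h; a higher number here means a weaker inhibitor, a lower number a stronger inhibitor. Compound 1, `COc1ccc(/C=C/C(=N\O)c2ccc(OC)cc2)cc1`, gives 12300 nM. Compound 2, `O/N=C(\C=C\c1ccc(Cl)cc1)c1ccc(Br)cc1`, gives 14700 nM. Compound 3, `O/N=C(\C=C\c1ccc(F)cc1)c1ccc(Br)cc1`, gives 13300 nM. Among the compounds with values here, on these three numbers compound 3 has the second highest value, but all three lie close together, and the one measured single-point step, a 1.1-fold lower number from compound 2 to compound 3 (0.04 log units; within the scatter), is itself within the scatter. In plain terms, none of the three can be called stronger or weaker than another on this evidence.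

Compound 4, `COc1ccc(/C=C/C(=N\O)c2ccc(Br)cc2)cc1`, has not yet been measured. Relative to compound 3 it differs in one place: methoxy in place of fluoro on an aromatic carbon. Within the data shown here, no measured step swaps these two groups directly. Among the measured compounds shown here, the only guidance is indirect: compound 1 carries methoxy on both outer rings and gives 12300 nM, which sits beside the value of compound 3 rather than apart from it, so a methoxy group in this family has not so far pulled the number far in either direction. The expected step is therefore a 1.1-fold lower number from compound 3 to compound 4 (0.03 log units; within the scatter), nothing beyond the scatter. Compound 4 is expected to give about 12500 nM, with a likely range from 6000 nM to 26000 nM.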

Compound 4, half-maximal inhibitory concentration: < 5000 nM
Compound 4: only a limit was reported; the forecaster's own chance of this, stated with the estimate: 5%; middle value at least 2.5-fold (0.39 log units) away from the limit.
By their numbers in this assay, from the lowest: compounds 1, 3 and 2 (each within the scatter of the next). At a limit, below all of these: compound 4.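

In this assay, methoxy in place of a halogen on this aromatic carbon, with bromo kept on the other outer ring, moves the number beyond the scatter, giving an at least 2.6-fold lower number from compound 3 to compound 4 (0.42 log units; beyond the scatter) and an at least 2.9-fold lower number from compound 2 to compound 4 (0.46 log units; beyond the scatter). Bromo in place of methoxy on the other ring also matters, giving an at least 2.4-fold lower number from compound 1 to compound 4 (0.39 log units; beyond the scatter), so among these four compounds only the pairing of methoxy with bromo stands apart, whereas the earlier compounds, with methoxy on both rings or a halogen on both, could not be told apart. From the compounds shown here alone, these steps give only a minimum size, and the true size stays unknown because compound 4 sits at a limit: the limit of < 5000 nM in this assay, at which 1 of the 4 values shown sits.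

Going by these compounds, how far the value of compound 4 truly lies past that limit remains open, and with it whether the pairing brings a large gain or a modest one. Also open, on these data alone, is whether the gain belongs to methoxy itself or would also appear with an ethoxy group, a hydroxyl or an amine on the same aromatic carbon, and whether it would survive with a carbonyl in place of the oxime.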